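The source may hold more compounds than are shown below. What is called first, only, known or untested is meant among the compounds shown, and "the series" means these compounds.

Measured so far:
compound 1 `Cc1nc(N2CCC(N3CCCS3(=O)=O)CC2)nc2ccc(NC(=O)/C=C/c3ccc(OC(F)(F)F)cc3)cc12` — 83%
compound 2 `C/C(=C\C(=O)Nc1ccc2nc(N3CCC(N4CCCC4=O)CC3)nc(C)c2c1)c1ccc(OC(F)(F)F)cc1` — 86%

In an ADME assay on microsomes from liver (Mus musculus) for metabolic stability, with a stated time of 30 min (a lower number here means that less of the compound is left, a higher number that more of the compound is left), compound 1 gives 83%; compound 2 gives 86%, a value within the usual scatter of that of compound 1, so the two numbers show no difference. Among the measured compounds shown here, no step between measured compounds is available.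

Compound 3 `Cc1nc(N2CCC(N3CCCC3=O)CC2)nc2ccc(NC(=O)/C=C/c3ccc(OC(F)(F)F)cc3)cc12` differs from compound 1 in one place: a group of 6 heavy atoms (4 carbon, 1 nitrogen, 1 oxygen; one five-membered non-aromatic ring with 1 hetero atom) in place of a group of 7 heavy atoms (3 carbon, 1 nitrogen, 2 oxygen, 1 sulfur; one five-membered non-aromatic ring with 2 hetero atoms), on a saturated ring carbon The entering 2-oxopyrrolidin-1-yl is also carried by compound 2, whose value sits within the scatter of compound 1. The step from compound 1 to compound 3 is therefore expected to be small, a number 2 percentage points higher from compound 1 to compound 3 (within the scatter), none beyond the scatter. Compound 3 is estimated at 85%, in the range 72% to 95%.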

Compound 3, percent of the compound remaining: 85%
Compound 3: middle estimate and measured number agree at the digits printed; the measured number falls inside the stated range.
By their numbers in this assay, from the lowest: compounds 1, 3 and 2 (each within the scatter of the next).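

On the saturated ring carbon three ring bonds from the ring nitrogen, 2-oxopyrrolidin-1-yl can replace the five-membered ring containing sulfur with no readable difference in this assay (a number 2 percentage points higher from compound 1 to compound 3 (within the scatter)). Unlike compound 1 and compound 2, which differ in more than one place, this pair isolates the group at this position. Nothing available bears on why the two compounds cannot be told apart. Still open, as far as these compounds go, is whether a different group on this carbon, such as an amine or a carboxylic acid, would give a similar number.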